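Swapping Chloro for Phenoxy on an Aromatic Ring

This account rests on a few compounds, and the source may have more. Where it says the series, first, only, none or still open, it means among the compounds named here.

In a functional assay on M21 cells (Homo sapiens) for antiproliferative activity, read by sulforhodamine B assay, with a stated time of 48 h (a higher number here means a weaker inhibitor, a lower number a stronger inhibitor), compound 1 `O=C1NCCN1c1ccc(S(=O)(=O)Nc2ccccc2)cc1` gives 200 nM, while compound 2 `O=C1NCCN1c1ccc(S(=O)(=O)Nc2cccc(Cl)c2)cc1` gives 25 nM, the lower of the two numbers and so the stronger inhibitor. Compound 3 `O=C1NCCN1c1ccc(S(=O)(=O)Nc2cccc(Oc3ccccc3)c2)cc1` keeps the shared core but has phenoxy in place of chloro on an aromatic carbon. Within the data shown here, only one measured step bears on this change: an 8.0-fold lower number from compound 1 to compound 2 (0.90 log units; beyond the scatter), a modest step beyond the scatter, made when chloro replaced hydrogen on that same carbon. Among the measured compounds shown here, that step shows that a group at this place can move the number, but no measured compound carries a second ring there, so the direction remains uncertain. A modest rise in this assay seems the likelier outcome, with the estimated step being a 3.2-fold higher number from compound 2 to compound 3 (0.51 log units; beyond the scatter). Compound 3 is expected at 80 nM, with an estimated range of 15 nM to 400 nM.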

Compound 3, half-maximal inhibitory concentration: 83 nM
Beside the measured number, compound 3's estimate is 1.0-fold (0.02 log units) below it, within the range that was stated.
By their numbers in this assay, from the lowest: compound 2; then compound 3; then compound 1.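

In this assay this aromatic carbon accepts a whole second ring and still holds part of the gain seen with chloro, with a 2.4-fold lower number from compound 1 to compound 3 (0.38 log units; beyond the scatter) as the change from the unsubstituted parent. Chloro nevertheless remains the better of the two groups here, with a 3.3-fold higher number from compound 2 to compound 3 (0.52 log units; beyond the scatter) as the cost of the swap, so the group with more heavy atoms does not give the lowest number among these three compounds. Nothing available here explains why chloro gives a lower number than phenoxy.

The compounds shown leave open how an amine, a carboxylic acid or a longer chain such as benzyloxy would behave on this same carbon. They also leave open whether a small group other than chloro, such as fluoro or methyl, could match or beat compound 2.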